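The source may report more compounds than this note shows. Statements on the series, on what has been measured and on what is new or still open speak of the compounds shown alone.

The compounds in this set share one core, carried on a sugar bearing four acetate groups. Compound 1 `CCCN1C(=O)C(O)(CC(=O)C[C@@H]2O[C@H](COC(C)=O)[C@@H](OC(C)=O)[C@H](OC(C)=O)[C@H]2OC(C)=O)c2ccccc21` in an ADME assay on Vero cells (Chlorocebus sabaeus) for cytotoxicity, read by resazurin assay, with a stated time of 72 h (on this read-out higher numbers stand for lower toxicity in this test and lower numbers for higher toxicity in this test), gives "not determined" (no result reported), and compound 2 `CC(=O)OC[C@H]1O[C@@H](CC(=O)CC2(O)C(=O)Nc3ccc(Cl)cc32)[C@H](OC(C)=O)[C@@H](OC(C)=O)[C@@H]1OC(C)=O` in this assay gives "not determined" (no result reported); for both no number was reported. For the measured compounds named here, compound 3 `CCCN1C(=O)/C(=C\C(=O)C[C@@H]2O[C@H](COC(C)=O)[C@@H](OC(C)=O)[C@H](OC(C)=O)[C@H]2OC(C)=O)c2ccccc21` is the one compound with a value: in this assay compound 3 gives 125000 nM, so it stands alone, with nothing measured to set beside it. Compound 4 `CC(=O)OC[C@H]1O[C@@H](CC(=O)/C=C2\C(=O)N(Cc3ccc(F)cc3)c3ccccc32)[C@H](OC(C)=O)[C@@H](OC(C)=O)[C@@H]1OC(C)=O` is the next step. The change from compound 3 to compound 4 is 4-fluorophenyl in place of ethyl on a saturated chain carbon bound to an amide-type nitrogen in a ring. Going by the values given here, no pair of measured compounds shows how such a change moves the read-out, so the expectation rests on compound 3 alone. The expected step, a 1.4-fold lower number from compound 3 to compound 4 (0.14 log units; within the scatter), is small and not clearly beyond the scatter. Compound 4 is therefore estimated at 90000 nM, within a range from 40000 nM to 200000 nM.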

Compound 4, half-maximal cytotoxic concentration: 119000 nM
Compound 4: middle estimate off by 1.3-fold (0.12 log units), on the low side; low and high end bracket the measured number.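

Putting 4-fluorophenyl in place of ethyl on a saturated chain carbon bound to an amide-type nitrogen in a ring gives a 1.1-fold lower number from compound 3 to compound 4 (0.02 log units; within the scatter) in this assay. This position therefore carries the larger group, with its aromatic ring, and the two compounds cannot be told apart on this read-out. Nothing measured here offers an explanation for this result. On these data alone, whether an unsubstituted benzyl, an amine or a carboxylic acid at this place would shift the number beyond the scatter remains open. So does the outcome of replacing the acetate groups on the sugar.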